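Isopropyl in Place of Hydrogen on the Ring Nitrogen

A few compounds are considered here, and "the series" means these few. Any claim that something is new, unique, unknown or untested is made for them only; others in the source may bear on it.

Of the compounds shown here, three have been measured in an assay on HEK293 cells for binding affinity to 5-hydroxytryptamine receptor 7 (Homo sapiens), read by radioligand binding, tested at 1 uM; a higher number here means more inhibition at the concentration tested (going by the name of the read-out), a lower number less inhibition. Compound 1 `CN1CCCN(CCn2ccc3ccc(Br)cc32)CC1` gives 93% in this assay; compound 2 `CN1CCCN(CCn2ccc3cc(Br)ccc32)CC1` gives 65%; compound 3 `Brc1ccc2ccn(CCN3CCCNCC3)c2c1` gives 77%. Compound 3 therefore stands second highest of the three: its nearest neighbour, compound 2, lies lower by a gap beyond the usual scatter, and compound 1 lies higher by a gap also beyond the scatter.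

Compound 4 `CC(C)N1CCCN(CCn2ccc3ccc(Br)cc32)CC1` differs from compound 3 in one place: isopropyl in place of hydrogen on an amine nitrogen in a ring. The change sits on the amine nitrogen of the seven-membered non-aromatic ring with 2 nitrogen, where compound 3 carries only a hydrogen.

For the measured compounds named here, one measured step bears on this. From compound 1 to compound 3, hydrogen took the place of methyl on that same nitrogen, and the result was a number 16 percentage points lower from compound 1 to compound 3 (beyond the scatter). So a small alkyl group on this nitrogen went with a higher number than a bare hydrogen. Isopropyl is a larger alkyl group than methyl, and no measured pair shows how a larger group behaves here, so the size of the effect is uncertain. Still, the step in this assay is expected to be upward and beyond the scatter, roughly reversing the earlier loss: a number 9 percentage points higher from compound 3 to compound 4 (within the scatter). Compound 4 is thus expected to give about 86% in this assay, within a range from 70% to 97%.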

Compound 4, a percentage reported as inhibition, at one concentration (the size of the read-out at that concentration, not a potency): 92%
Beside the measured number, compound 4's estimate is 6 percentage points below it; low and high end bracket the measured number.
By their numbers in this assay, from the lowest: compound 2; then compound 3; then compounds 4 and 1 (each within the scatter of the next).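

In this assay, isopropyl on this amine nitrogen in a ring gives a number 15 percentage points higher from compound 3 to compound 4 (beyond the scatter), which is the opposite direction to the earlier a number 16 percentage points lower from compound 1 to compound 3 (beyond the scatter). The change from the smaller alkyl group to the larger one gives a number 1 percentage points lower from compound 1 to compound 4 (within the scatter), so at this nitrogen methyl and isopropyl cannot be told apart in this read-out, while both stand clear of the bare hydrogen of compound 3, and the gain seen so far with methyl alone now appears with a second, larger alkyl group. Nothing at hand explains why an alkyl group here goes with a higher number.

Going by these compounds, whether a benzyl group, a longer chain or an acetyl group on this nitrogen would keep the number as high remains open, as does whether isopropyl would bring a similar rise on the core of compound 2, which carries the bromine elsewhere. A reading at one concentration is also not a potency, so compound 1 and compound 4 could still differ in a full concentration series.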